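The source may report more compounds than this note shows. Statements on the series, on what has been measured and on what is new or still open speak of the compounds shown alone.

Compound 3 `N#CN/C(=N\C1CCCC1)Nc1cccnc1` is one of three measured compounds that share the same core and differ only in the group held on the double-bonded nitrogen. In a functional assay on the whole organism (blood, strain Wistar-Okamoto) with Rattus norvegicus as the target, with a stated time of 5 days (a higher number here means that more compound is needed for the effect, a lower number that less compound is needed), compound 3 gives 20 mg/kg. Compound 1 `CCCC/N=C(\NC#N)Nc1cccnc1` gives 20 mg/kg in this assay, and compound 2 `CCC(CC)/N=C(\NC#N)Nc1cccnc1` gives 20 mg/kg, so compound 3 stands level with both at the digits shown. The three steps among them agree: no change at the digits printed from compound 1 to compound 2 (within the scatter), no change at the digits printed from compound 1 to compound 3 (within the scatter), and no change at the digits printed from compound 2 to compound 3 (within the scatter).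

Compound 4 `CCCC(C)(C)/N=C(\NC#N)Nc1cccnc1` takes the next step from compound 3: 1,1-dimethylbutyl in place of cyclopentyl on a double-bonded nitrogen. All three measured steps swap one alkyl group for another on this nitrogen, one of them also trading a ring for an open chain, and none moved the readout beyond the scatter. The step to compound 4 is of the same kind, so no shift beyond the scatter is expected in this assay, and the estimated step is no change at the digits printed from compound 3 to compound 4 (within the scatter). Compound 4 is therefore expected to give about 20 mg/kg, with a likely range from 10 mg/kg to 40 mg/kg.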

Compound 4, minimum effective dose: 1 mg/kg
Beside the measured number, compound 4's estimate is 20-fold (1.30 log units) above it; measured number outside the range, below it.
By their numbers in this assay, from the lowest: compound 4; then compounds 1, 2 and 3 (each within the scatter of the next).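

The group on this double-bonded nitrogen can matter a great deal: in this assay the change to 1,1-dimethylbutyl gives a 20-fold lower number from compound 3 to compound 4 (1.30 log units; beyond the scatter) and also a 20-fold lower number from compound 2 to compound 4 (1.30 log units; beyond the scatter) as well as a 20-fold lower number from compound 1 to compound 4 (1.30 log units; beyond the scatter) with the same replacement. Butyl, pentan-3-yl and cyclopentyl had stayed level with one another, so the earlier compounds gave no sign that this position could respond so strongly. Losing the ring cannot be enough on its own, since butyl and pentan-3-yl also carry no ring and still stay level with cyclopentyl.

A tert-butyl group or a 1,1-dimethylpentyl chain at this nitrogen would show how much of the 1,1-dimethylbutyl group the lower number requires. Nothing measured here says why this group stands apart.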